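The source may report more compounds than this note shows. Statements on the series, on what has been measured and on what is new or still open speak of the compounds shown alone.

Among the measured compounds shown here, compound 1 `CCOC(=O)c1[nH]c(=O)c(C#N)cc1C(=O)c1ccccc1` holds the only actual number: in an ADME assay on J774.A1 cells (Mus musculus) for cytotoxicity, read by MTT assay, with a stated time of 48 h (a lower number here means that less compound is tolerated, a higher number that more compound is tolerated), compound 1 gives 215000 nM. Compound 2 `CCOC(=O)c1[nH]c(=O)c(C#N)cc1C(=O)c1ccc(Cl)cc1` reaches only a limit in this assay, < 100000 nM. Compound 3 `CCOC(=O)c1[nH]c(=O)c(C#N)cc1C(=O)c1ccc([N+](=O)[O-])cc1` likewise reaches only a limit in this assay, < 100000 nM. The two measured steps from compound 1 both run toward that limit: an at least 2.1-fold lower number from compound 1 to compound 2 (0.33 log units; beyond the scatter) and an at least 2.1-fold lower number from compound 1 to compound 3 (0.33 log units; beyond the scatter). The step between the two limits, a step that the two limits leave unreadable from compound 2 to compound 3, cannot be read. The shared feature of the measured evidence is the limit of < 100000 nM in this assay, at which 2 of the 3 values shown sit, which caps both substituted compounds.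

Compound 4 `CCOC(=O)c1[nH]c(=O)c(C#N)cc1C(=O)c1ccc(OC)cc1` differs from compound 1 by methoxy in place of hydrogen on an aromatic carbon. The two measured changes at the same place, chloro and nitro, each lowered the number at least modestly, and methoxy is a third substituent at that place. The expectation is therefore a step downward from compound 1 to compound 4 of about the same order, a 2.0-fold lower number from compound 1 to compound 4 (0.29 log units; within the scatter), with a real chance that this assay again reports only a limit. Compound 4 is estimated at 110000 nM, within a range of 50000 nM to 260000 nM.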

Compound 4, half-maximal cytotoxic concentration: < 100000 nM
Compound 4 gave a limit, no number; the forecaster's own chance of this, stated with the estimate: 50%; at least 1.1-fold (0.04 log units) between middle value and limit.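

Going from phenyl to 4-methoxyphenyl, on an aromatic carbon para to a large group, gives an at least 2.1-fold lower number from compound 1 to compound 4 (0.33 log units; beyond the scatter) in this assay; the value of compound 4 is a limit and not a number, so this step sets only a minimum size. Methoxy is now the third group at this place, after chloro and nitro, to end at a limit rather than at an actual number, and none of the compounds shown goes against this pattern, with compound 1, which carries no substituent at this place, remaining the only compound with a number. The limit therefore now covers every substituted compound shown and is the main feature of the series so far: the limit of < 100000 nM in this assay, at which 3 of the 4 values shown sit.

Going by these compounds, the steps among compound 2, compound 3 and compound 4 cannot be read, so the order of chloro, nitro and methoxy at this place and the true size of each step from compound 1 remain unknown. On these data alone, it also remains open whether an amine, a carboxylic acid or a longer chain such as ethoxy at the same place would give an actual number or reach the same limit.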